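A few compounds are considered here, and "the series" means these few. Any claim that something is new, unique, unknown or untested is made for them only; others in the source may bear on it.

Measured so far in a functional assay on MKN-74 cells (Homo sapiens) for antiproliferative activity, with a stated time of 24 h; a lower number here means a stronger inhibitor, a higher number a weaker inhibitor: compound 1 `NC(=O)c1c(NC(=O)c2ccc(C(F)(F)F)cc2)sc2c1CCN(Cc1ccc(Cl)cc1Cl)C2` gives 10900 nM; compound 2 `Cc1ccc(C(=O)Nc2sc3c(c2C(N)=O)CCN(Cc2ccc(Cl)cc2Cl)C3)cc1` gives 25500 nM; compound 3 `NC(=O)c1c(NC(=O)c2ccc(C(F)(F)F)cc2)sc2c1CCN(C(=S)Nc1cc(C(F)(F)F)cc(C(F)(F)F)c1)C2` gives 13800 nM.

Compounds 1 and 2 differ in one place: methyl in place of trifluoromethyl on an aromatic carbon. This change gives a 2.3-fold higher number from compound 1 to compound 2 (0.37 log units; beyond the scatter). Compound 3 shares the same amide-bearing part as compound 1 but differs from it elsewhere; the difference between the two cores is not broken down here. The value of compound 3 lies within the scatter of both compound 1 and compound 2 in this assay.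

Compound 4 `Cc1ccc(C(=O)Nc2sc3c(c2C(N)=O)CCN(C(=S)Nc2cc(C(F)(F)F)cc(C(F)(F)F)c2)C3)cc1` has not yet been measured. It stands to compound 3 as compound 2 stands to compound 1: methyl in place of trifluoromethyl on an aromatic carbon, the same change at the same kind of place. Among the compounds with values here, on the single earlier step from compound 1 to compound 2, compound 3 is expected to move by a 2.2-fold higher number from compound 3 to compound 4 (0.34 log units; beyond the scatter) toward a weaker inhibitor. Compound 4 is therefore estimated at 30000 nM, with a likely range from 14000 nM to 65000 nM; this rests on one pair only.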

Compound 4, half-maximal inhibitory concentration: 14900 nM
Beside the measured number, compound 4's estimate is 2.0-fold (0.30 log units) above it; low and high end bracket the measured number.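

In this assay, methyl in place of trifluoromethyl gives a 1.1-fold higher number from compound 3 to compound 4 (0.03 log units; within the scatter), so no effect of the change can be read on the core of compound 3. Set beside the earlier step, this result does not separate the two cores: the same change on two cores in this assay, a 2.3-fold higher number (0.37 log units; beyond the scatter) from compound 1 to compound 2 and a 1.1-fold higher number (0.03 log units; within the scatter) from compound 3 to compound 4, 2.2-fold (0.34 log units) apart, within the scatter of two such steps. The change can therefore be said to carry over without a detectable conflict, but two pairs show neither that the step is the same on both cores nor that it depends on the core.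

The compounds shown leave open how a chlorine, a methoxy group or a nitrile at the same place would compare on these two cores. They also leave open whether the step would hold on a third core.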